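Isobutyl addition to the core of compound 1

The source may report more compounds than this note shows. Statements on the series, on what has been measured and on what is new or still open speak of the compounds shown alone.

Compound 1 `Cc1cc2c(c(C)c1N)CC(C)(C)O2` gives 16.3 mg/kg in a functional assay on the whole organism with Mus musculus as the target (a lower number here means that less compound is needed, a higher number that more compound is needed for the effect), and compound 3 `Cc1c(C)c2c(c(N(C)C)c1N)CC(C)(C)O2` gives 22.3 mg/kg, within the scatter of compound 1. Compound 2 `Cc1c(C)c2c(c(N)c1N)CC(C)(C)O2` reaches only > 50 mg/kg, a limit of the assay, (the limit of > 50 mg/kg in this assay, at which 1 of the 3 values shown sits). Going by the values given here, the one measured step, an at least 2.2-fold lower number from compound 2 to compound 3 (0.35 log units; beyond the scatter), concerns the amino group alone. Compound 4 `Cc1c(N)c(C)c2c(c1CC(C)C)OC(C)(C)C2` differs from compound 1 by isobutyl in place of hydrogen on an aromatic carbon. Among the compounds with values here, no measured step exchanges an aromatic hydrogen for an alkyl chain, so that step does not bear directly on the change, and the series gives no guide to direction. The expectation for compound 4 is therefore a step within the scatter, a 1.1-fold higher number from compound 1 to compound 4 (0.04 log units; within the scatter), with wide uncertainty. Compound 4 is estimated at 18 mg/kg, between 8 mg/kg and 45 mg/kg.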

Compound 4, dose for 50% inhibition: 13.3 mg/kg
For compound 4 the middle estimate is 1.4-fold (0.13 log units) above the measured one; low and high end bracket the measured number.
By their numbers in this assay, from the lowest: compounds 4, 1 and 3 (each within the scatter of the next). At a limit, above all of these: compound 2.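

In this assay, isobutyl in place of hydrogen on an aromatic carbon, ortho to a fused ring and ortho to a methyl group, gives a 1.2-fold lower number from compound 1 to compound 4 (0.09 log units; within the scatter). Going by these compounds alone, this position on the core of compound 1 thus accepts an isobutyl chain with the number still within the scatter, which no earlier step addressed. No recorded measurement bears on this step. From the compounds shown here alone, whether a longer chain, an amine or a carboxylic acid at this position would also stay within the scatter remains open. A single step gives no trend with chain size.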